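Fluoro-to-hydroxy swap in the sulfonamide series

The compounds below may be only part of what the source reports. "The series", "measured", "known", "first", "only" and "open" are said of these compounds alone.

Measured compounds:
compound 1 `CN1CCN(Cc2ccc(Nc3ncc(Cl)c(Nc4ccccc4S(=O)(=O)N4CCCC4)n3)cc2)CC1` gives 19 nM in an assay on isolated protein for inhibition of tyrosine-protein kinase receptor UFO (Homo sapiens), read by TR-FRET, with a stated time of 60 min; on this read-out lower numbers stand for stronger inhibition and higher numbers for weaker inhibition
compound 2 `CN1CCN(Cc2ccc(Nc3ncc(Cl)c(Nc4ccc(F)cc4S(=O)(=O)N4CCOCC4)n3)cc2)CC1` gives 240 nM in this assay
compound 3 `CN1CCN(Cc2ccc(Nc3ncc(Cl)c(Nc4ccc(F)cc4S(=O)(=O)N4CCCC4)n3)cc2)CC1` gives 37 nM in this assay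

Compound 3 stands second highest of the three numbers. Its nearest neighbour is compound 1, and the step of a 1.9-fold higher number from compound 1 to compound 3 (0.29 log units; within the scatter) lies within the scatter. Its furthest neighbour is compound 2, and the step of a 6.5-fold lower number from compound 2 to compound 3 (0.81 log units; beyond the scatter) lies beyond the scatter, though it concerns the group on the sulfonyl sulfur, not the aromatic position at issue here.

Compound 4 `CN1CCN(Cc2ccc(Nc3ncc(Cl)c(Nc4ccc(O)cc4S(=O)(=O)N4CCCC4)n3)cc2)CC1` is the next compound: hydroxy in place of fluoro on an aromatic carbon, on an aromatic carbon of a six-membered aromatic ring of carbon only, meta to a (pyrrolidin-1-yl)sulfonyl group and para to a large group. Going by the values given here, the only measured step at this carbon is the one from hydrogen to fluoro, which stayed within the scatter; nothing measured bears on a hydroxy group there. In this assay compound 4 is therefore expected to show a step of about a 1.1-fold higher number from compound 3 to compound 4 (0.03 log units; within the scatter), in no particular direction and not clearly beyond the scatter, with a wider range to allow for the untested group. The estimate for compound 4 is 40 nM, within 14 nM to 115 nM.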

Compound 4, half-maximal inhibitory concentration: 1320 nM
Compound 4: middle estimate off by 33-fold (1.52 log units), on the low side; the measured number lies above the stated range.
By their numbers in this assay, from the lowest: compounds 1 and 3 (each within the scatter of the next); then compound 2; then compound 4.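

In this assay this aromatic carbon turns out to be far from indifferent: the change from hydrogen to fluoro had stayed within the scatter, whereas hydroxy in place of fluoro gives a 36-fold higher number from compound 3 to compound 4 (1.55 log units; beyond the scatter) and hydroxy in place of hydrogen gives a 69-fold higher number from compound 1 to compound 4 (1.84 log units; beyond the scatter) in the same direction. Among the three groups seen at this carbon, hydrogen and fluoro cannot be told apart, and only hydroxy, the one of the three that brings a hydrogen-bond donor and a hydrogen-bond acceptor by the count, stands clearly apart, so the earlier flat step said nothing about how the carbon responds to other groups. No measurement on hand explains the size of this loss.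

The compounds shown leave open whether the loss goes with the hydrogen-bond donor of the hydroxy group or with the oxygen itself, a question that a methoxy group or an amine on the same carbon would help to separate. They also leave open whether hydroxy at this carbon costs as much with morpholin-4-yl on the sulfonyl sulfur as it does with pyrrolidin-1-yl.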